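Urea aryl swap on a cyclohexyl ether scaffold

The source may report more compounds than this note shows. Statements on the series, on what has been measured and on what is new or still open speak of the compounds shown alone.

Measured so far:
- Compound 1, `O=C(Nc1ccc(Cl)cc1)N[C@H]1CC[C@H](Oc2ccc(F)cc2)CC1`: in a functional assay on CRL2813 cells (Homo sapiens) for cytotoxicity, read by sulforhodamine B assay, with a stated time of 5 days (on this read-out higher numbers stand for weaker inhibition and lower numbers for stronger inhibition), compound 1 reaches only the limit > 20000 nM.
- Compound 2, `Cc1cccc(NC(=O)N[C@H]2CC[C@H](Oc3ccc(F)cc3)CC2)c1`: compound 2 gives 14400 nM.
- Compound 3, `O=C(Nc1ccccc1Cl)N[C@H]1CC[C@H](Oc2ccc(F)cc2)CC1`: compound 3 gives 9100 nM.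

Compound 3 gives the lower of the two actual numbers, but the gap to compound 2 is small, a 1.6-fold lower number from compound 2 to compound 3 (0.20 log units; within the scatter). Compound 1 gives only a limit, (the limit of > 20000 nM in this assay, at which 1 of the 3 values shown sits), so its step to compound 3 is a floor, an at least 2.1-fold lower number from compound 1 to compound 3 (0.34 log units; beyond the scatter), and to compound 2 likewise, an at least 1.3-fold lower number from compound 1 to compound 2 (0.14 log units; that floor lies within the scatter).

Compound 4, `COc1ccc(NC(=O)N[C@H]2CC[C@H](Oc3ccc(F)cc3)CC2)cc1`, is not yet measured. It differs from compound 3 in one place: 4-methoxyphenyl in place of 2-chlorophenyl on an amide-type nitrogen. The measured steps that bear on this all change the aryl group on the same nitrogen. Moving the chlorine from the 4-chlorophenyl of compound 1 to the 2-chlorophenyl of compound 3 lowered the number beyond the scatter, and the 3-methylphenyl of compound 2 sits between. Compound 4 returns to a 4-substituted aryl, as in compound 1, so the expectation is a move back toward the region of compound 1 and compound 2, with the step expected to be a 1.8-fold higher number from compound 3 to compound 4 (0.25 log units; within the scatter). Compound 4 is therefore estimated at 16000 nM, in a range from 7000 nM to 40000 nM.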

Compound 4, half-maximal inhibitory concentration: > 20000 nM
Compound 4: a limit, no number (the forecaster's own chance of this, stated with the estimate: 35%); middle value at least 1.2-fold (0.09 log units) from the limit.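

In this assay compound 4 gives only a limit, not a number, and it is the second compound to do so: the limit of > 20000 nM in this assay, at which 2 of the 4 values shown sit. The change to 4-methoxyphenyl on the amide-type nitrogen gives an at least 2.1-fold higher number from compound 3 to compound 4 (0.34 log units; beyond the scatter), a floor that already clears the scatter, whereas the floor of an at least 1.3-fold higher number from compound 2 to compound 4 (0.14 log units; that floor lies within the scatter) does not separate the two compounds. The new result shows that reaching the limit is not confined to the 4-chlorophenyl of compound 1, as a 4-methoxyphenyl also does so, while the 2-chlorophenyl of compound 3 and the 3-methylphenyl of compound 2 both give readable numbers, although two 4-substituted aryl groups are too few to establish a rule.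

The two limits leave the step from compound 1 to compound 4 unreadable, so the compounds shown cannot rank chloro against methoxy on that aromatic carbon. Also open, on these data alone, is whether an amine or a carboxylic acid in place of the methoxy on this aryl group would bring the value back to a readable number in this assay.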